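Inverting the Stereocentre of Compound 2

The compounds below may be only part of what the source reports. "The series", "measured", "known", "first", "only" and "open" are said of these compounds alone.

Compound 2 `COc1ccc(Cl)cc1NC(=O)[C@@H](C)N1CCN(S(=O)(=O)N2CCC(C(F)(F)F)CC2)CC1` is one of three compounds tested in an assay on HEK293 cells for inhibition of potassium channel subfamily T member 1 (Homo sapiens), read by thallium flux; on this read-out lower numbers stand for stronger inhibition and higher numbers for weaker inhibition. Compound 2 gives 3500 nM, which stands as the highest of the two numbers reported; its nearest neighbour is compound 1 `COc1ccc(Cl)cc1NC(=O)CN1CCN(S(=O)(=O)N2CCN(S(=O)(=O)c3ccc(Cl)cc3)CC2)CC1`, which in this assay gives 2300 nM, a gap that lies within the scatter. The third compound, compound 3 `CCCC1CCN(C(=O)N2CCN(S(=O)(=O)N3CCN(CC(=O)Nc4cc(Cl)ccc4OC)CC3)CC2)CC1`, gives in this assay only a limit of the assay, > 10000 nM (the limit of > 10000 nM in this assay, at which 1 of the 3 values shown sits). Going by the values given here, the single measured step, an at least 4.3-fold higher number from compound 1 to compound 3 (0.63 log units; beyond the scatter), shows a (4-propylpiperidin-1-yl)carbonyl in place of a (4-chlorophenyl)sulfonyl and does not concern the change considered here.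

Compound 4 `COc1ccc(Cl)cc1NC(=O)[C@H](C)N1CCN(S(=O)(=O)N2CCC(C(F)(F)F)CC2)CC1` is not yet measured in this assay. It differs from compound 2 as follows: the two compounds have the same atoms and bonds and differ only in configuration as drawn: 1 of 1 stereo elements differ; a stereocentre at a saturated chain carbon is drawn R in compound 2 and S in compound 4. Among the compounds with values here, no measured step in this set involves a change of configuration, so nothing here indicates the direction or size of the effect, and the expectation must rest on the value of compound 2 alone, with wide uncertainty in either direction and a real chance of a limit.

On that basis compound 4 is expected to give about 5000 nM in this assay, within a range from 1000 nM to 10000 nM. The estimated step is a 1.4-fold higher number from compound 2 to compound 4 (0.15 log units; within the scatter).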

Compound 4, half-maximal inhibitory concentration: 3400 nM
For compound 4 the middle estimate is 1.5-fold (0.17 log units) above the measured one; the range from low to high includes it.
By their numbers in this assay, from the lowest: compounds 1, 4 and 2 (each within the scatter of the next). At a limit, above all of these: compound 3.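

In this assay, inverting the stereocentre gives a 1.0-fold lower number from compound 2 to compound 4 (0.01 log units; within the scatter), so the R and S forms drawn at this saturated chain carbon cannot be told apart on this read-out. The earlier compounds could say nothing about configuration, since the only step among them exchanged a (4-chlorophenyl)sulfonyl for a (4-propylpiperidin-1-yl)carbonyl, whereas this pair isolates the stereocentre as the single variable, and the comparison is a clean one for this reason: the fact that compounds 2 and 4 differ only in the configuration as drawn

For this pair, then, the drawn configuration at this position is not what sets the value, and any inhibition of the channel seen with this scaffold is as well served by one form as by the other. The compounds shown leave open whether this carries over when the carbon bears an ethyl group, a hydroxymethyl group or a longer chain, where the two configurations might read apart. They also leave open whether the same holds for an inverted stereocentre in a compound with a different group on the far sulfonyl side, such as the partners in compound 1 and compound 3.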